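One group swapped: from compound 2 to compound 4

This account rests on a few compounds, and the source may have more. Where it says the series, first, only, none or still open, it means among the compounds named here.

Going by the values given here, in a functional assay on MCF7 cells (Homo sapiens) for cytotoxicity, read by CellTiter-Glo, with a stated time of 5 days (on this read-out lower numbers stand for stronger inhibition and higher numbers for weaker inhibition), compound 2 `CC/C(=C(/c1ccc(/C=C/C(=O)O)cc1)c1ccc2[nH]c(=O)sc2c1)c1ccccc1` gives 158 nM and stands as the higher of the two numbers so far. Compound 3 `CC/C(=C(/c1ccc(/C=C/C(=O)O)cc1)c1cccc2[nH]ncc12)c1ccccc1` gives 21 nM and sits lower. For compound 1 `CC/C(=C(/c1ccc(/C=C/C(=O)O)cc1)c1ccc(O)nc1)c1ccccc1` the entry is "not determined" (no result reported) and so adds nothing to the comparison. Compound 4 `CC/C(=C(/c1ccc(/C=C/C(=O)O)cc1)c1ccc2cn[nH]c2c1)c1ccccc1` has not yet been measured. It alters one part of compound 2 as follows: a group of 9 heavy atoms (7 carbon, 2 nitrogen; one five-membered aromatic ring with 2 hetero atoms, one six-membered aromatic ring of carbon only) in place of a group of 10 heavy atoms (7 carbon, 1 nitrogen, 1 oxygen, 1 sulfur; one five-membered aromatic ring with 2 hetero atoms, one six-membered aromatic ring of carbon only), on a double-bonded chain carbon bound to an aromatic carbon and a double-bonded chain carbon and the entering group is 1H-indazol-6-yl. Among the compounds with values here, the one measured step bearing on this is a 7.5-fold lower number from compound 2 to compound 3 (0.88 log units; beyond the scatter) and it also brought in a group of 9 heavy atoms with 7 carbon and 2 nitrogen, though not this same group, so a drop in the same direction but of smaller size is expected. Within the data shown here, no measurement yet tests 1H-indazol-6-yl directly. The expectation is thus an estimated 3.5-fold lower number from compound 2 to compound 4 (0.55 log units; beyond the scatter) in this assay for now. Compound 4 is expected at 45 nM with an estimated range from 15 nM to 140 nM for four of five measurements.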

Compound 4, half-maximal inhibitory concentration: 570 nM
The estimate for compound 4 lay 13-fold (1.10 log units) below the measured number; measured number above the stated range.
By their numbers in this assay, from the lowest: compound 3; then compound 2; then compound 4.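

In this assay, two groups with the same count of carbon and nitrogen atoms behave very differently at this place: putting 1H-indazol-6-yl in place of 1H-indazol-4-yl gives a 27-fold higher number from compound 3 to compound 4 (1.43 log units; beyond the scatter). Bringing in a group of this kind is therefore no guarantee of a lower number, since 1H-indazol-6-yl gives a 3.6-fold higher number from compound 2 to compound 4 (0.56 log units; beyond the scatter), while 1H-indazol-4-yl went the other way with a 7.5-fold lower number from compound 2 to compound 3 (0.88 log units; beyond the scatter). Nothing available explains why these two groups differ so much.

The compounds shown leave open how 1H-indazol-5-yl, or a simpler group such as an amine, would rank at this double-bonded chain carbon. The group in compound 1 also remains unplaced, as compound 1 gives "not determined" (no result reported).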